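Swapping the aryl ring on a carbamate monoglyceride lipase inhibitor

The source may report more compounds than this note shows. Statements on the series, on what has been measured and on what is new or still open speak of the compounds shown alone.

Three carbamates sharing one core have been measured in an assay on isolated protein for inhibition of Monoglyceride lipase (Rattus norvegicus), read by fluorescence, with stated times of 15 min and 3 h; a lower number here means a stronger inhibitor, a higher number a weaker inhibitor. Compound 1 `N#Cc1cc(O)cc(OC(=O)N2CCC(C(c3ccccc3)c3ccccc3)CC2)c1` gives 98.2 nM, compound 2 `N#Cc1ccc(F)c(OC(=O)N2CCC(C(c3ccccc3)c3ccccc3)CC2)c1` gives 112 nM, and compound 3 `N#Cc1cccc(OC(=O)N2CCC(C(c3ccccc3)c3ccccc3)CC2)n1` gives 75.8 nM. Compound 3 holds the lowest of the three numbers, yet every step toward it is small: a 1.3-fold lower number from compound 1 to compound 3 (0.11 log units; within the scatter) and a 1.5-fold lower number from compound 2 to compound 3 (0.17 log units; within the scatter), so no order among the three can be claimed.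

Compound 4 `N#Cc1cc(F)cc(OC(=O)N2CCC(C(c3ccccc3)c3ccccc3)CC2)c1` is the next candidate. Relative to compound 3 the change is 3-cyano-5-fluorophenyl in place of 6-cyanopyridin-2-yl on an oxygen next to a carbonyl group. For the measured compounds named here, two measured steps bear on this: a 1.5-fold lower number from compound 2 to compound 3 (0.17 log units; within the scatter), where a cyano-fluorophenyl ring was traded for the cyanopyridinyl ring, and a 1.3-fold lower number from compound 1 to compound 3 (0.11 log units; within the scatter), where a cyano-hydroxyphenyl ring was traded for it. Both fell within the scatter, and the change from compound 1 to compound 2, a hydroxy exchanged for a fluorine, was also within the scatter (a 1.1-fold higher number from compound 1 to compound 2 (0.06 log units; within the scatter)). The step to compound 4 is therefore expected to be no larger than the scatter, in either direction, giving a 1.3-fold higher number from compound 3 to compound 4 (0.12 log units; within the scatter). Compound 4 is estimated at 100 nM, with a range from 50 nM to 200 nM.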

Compound 4, half-maximal inhibitory concentration: 105 nM
The estimate for compound 4 lay 1.1-fold (0.02 log units) below the measured number, and the stated range covers the measured number.
By their numbers in this assay, from the lowest: compounds 3, 1, 4 and 2 (each within the scatter of the next).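

Compound 4 puts 3-cyano-5-fluorophenyl on the oxygen next to a carbonyl group, and replacing 6-cyanopyridin-2-yl, with its ring nitrogen, by this ring of carbon only stays within the scatter (a 1.4-fold higher number from compound 3 to compound 4 (0.14 log units; within the scatter)). Two cyano-fluoro rings can now be compared directly, and exchanging 5-cyano-2-fluorophenyl for 3-cyano-5-fluorophenyl is also within the scatter (a 1.1-fold lower number from compound 2 to compound 4 (0.03 log units; within the scatter)), so where these two groups sit on the ring makes no measurable difference in this pair. The cleanest change so far, fluoro in place of hydroxy on an aromatic carbon, likewise stays within the scatter (a 1.1-fold higher number from compound 1 to compound 4 (0.03 log units; within the scatter)), so all four rings remain indistinguishable here.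

Nothing available explains why these exchanges change so little. On these data alone, whether an amine or a carboxylic acid on this ring, or a ring without the nitrile, would move the number beyond the scatter remains open.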